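The source may hold more compounds than are shown below. What is called first, only, known or untested is meant among the compounds shown, and "the series" means these compounds.

Measured so far in a functional assay on A2780 cells (Homo sapiens) for antiproliferative activity, read by resazurin assay, with a stated time of 72 h; on this read-out higher numbers stand for weaker inhibition and lower numbers for stronger inhibition:
- compound 1 `CCCN(C)C(=O)c1cc2c(Cc3ccccc3)n[nH]c2cc1O` gives > 10000 nM.
- compound 2 `Cc1ccccc1CN(C)C(=O)c1cc2c(Cc3ccccc3)n[nH]c2cc1O` gives 4400 nM.
- compound 3 `CN(Cc1ccccc1)C(=O)c1cc2c(Cc3ccccc3Cl)n[nH]c2cc1O` gives "not determined" (no result reported).

The value of compound 1 in this assay is a limit of the assay, not a number; (the limit of > 10000 nM in this assay, at which 1 of the 3 values shown sits). Compound 2 stands at a measured number, and the step of an at least 2.2-fold lower number from compound 1 to compound 2 (0.35 log units; beyond the scatter) follows the change 2-methylphenyl in place of ethyl on a saturated chain carbon bound to an amide-type nitrogen. Compound 3 has no result in this assay, so it stands nowhere on the numbers shown; it shares with compound 2 the amide part bearing a benzyl-type group and differs from it at the other end of the shared core.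

Compound 4 `CN(Cc1ccccc1)C(=O)c1cc2c(CCc3ccccc3)n[nH]c2cc1O` is not yet measured. Compared with compound 3 it carries benzyl in place of 2-chlorophenyl on a saturated chain carbon bound to an aromatic carbon. Going by the values given here, none of the measured steps touches this position: the only step recorded, an at least 2.2-fold lower number from compound 1 to compound 2 (0.35 log units; beyond the scatter), sits on the amide nitrogen side, and compound 3 itself gives no number. No direction or size of step in this assay can therefore be drawn from the data for the change from compound 3 to compound 4.

Compound 4 is expected to land near the measured number of compound 2, and its value in this assay is estimated at 5000 nM, with a range from 1500 nM to 20000 nM.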

Compound 4, half-maximal inhibitory concentration: 4600 nM
Beside the measured number, compound 4's estimate is 1.1-fold (0.04 log units) above it; the measured number falls inside the stated range.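

No step can be read between compound 3, which gives "not determined" (no result reported), and compound 4, which gives 4600 nM. No evidence shown bears on this result. The compounds shown leave open whether 2-chlorobenzyl and phenethyl differ in antiproliferative activity on the shared core with the same amide part.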